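The compounds below may be only part of what the source reports. "The series", "measured", "known", "first", "only" and "open" are said of these compounds alone.

Of the compounds shown here, three with a shared core have been measured in a functional assay on UO-31 cells (Homo sapiens) for inhibition, read by sulforhodamine B assay, with a stated time of 48 h; on this read-out higher numbers stand for weaker inhibition of growth and lower numbers for stronger inhibition of growth. Compound 1, `Nc1cc(N)c2nc(-c3ccccc3)c(Oc3ccc(Cl)c(Cl)c3)nc2c1`, gives 4070 nM in this assay, the lowest of the three numbers. Compound 2, `COc1cc(CNc2nc3cc(N)cc(N)c3nc2-c2ccccc2)cc(OC)c1OC`, gives 11200 nM, and compound 3, `CCOC(=O)[C@H](CCC(=O)O)NC(=O)c1ccc(Oc2nc3cc(N)cc(N)c3nc2-c2ccccc2)cc1`, gives 11200 nM; both stand beyond the scatter from compound 1, so compound 1 inhibits growth more strongly than either of them, while compounds 2 and 3 cannot be told apart from each other.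

The next compound, compound 4, `Nc1cc(N)c2nc(-c3ccccc3)c(Oc3ccc(F)cc3)nc2c1`, differs from compound 1 in one place: 4-fluorophenyl in place of 3,4-dichlorophenyl on an oxygen on an aromatic ring. Among the measured compounds shown here, no pair among the measured compounds shows this exchange, so nothing measured here tells how large its effect is. In the absence of such a pair, a modest step is expected, toward weaker inhibition of growth, of a size that could still fall within the scatter. Compound 4 is accordingly expected to give about 7000 nM in this assay, within a range from 2500 nM to 20000 nM. That estimate corresponds to a step of a 1.7-fold higher number from compound 1 to compound 4 (0.24 log units; within the scatter).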

Compound 4, concentration for 50% growth inhibition: 13500 nM
The estimate for compound 4 lay 1.9-fold (0.29 log units) below the measured number, and the stated range covers the measured number.
By their numbers in this assay, from the lowest: compound 1; then compounds 2, 3 and 4 (each within the scatter of the next).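

In this assay, 4-fluorophenyl in place of 3,4-dichlorophenyl on the oxygen gives a 3.3-fold higher number from compound 1 to compound 4 (0.52 log units; beyond the scatter), a weakening of growth inhibition. Among the compounds shown here, compounds 1 and 4 are the only pair here that differ in one place, so this step is the first direct sign that the group on this oxygen matters for inhibition of growth in these cells. Nothing measured here explains the size or direction of this step.

The exchange changes both the number and the kind of halogen on the ring, so the compounds shown do not separate the loss of the two chlorines from the arrival of the fluorine. A plain phenyl or a phenyl carrying a single chlorine on the same oxygen would help to separate these two changes.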